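From Dichlorophenyl to Dimethoxyphenyl on the Carbonyl Carbon

This account rests on a few compounds, and the source may have more. Where it says the series, first, only, none or still open, it means among the compounds named here.

Compound 1 `COc1cc(-c2cc(/C=C/C(=O)c3ccc(N)cc3)[nH]n2)cc(OC)c1OC` carries a 4-aminophenyl on the carbonyl carbon, and in a functional assay on UACC-62 cells (Homo sapiens) for inhibition, read by sulforhodamine B assay, with a stated time of 48 h (a higher number here means a weaker inhibitor of growth, a lower number a stronger inhibitor of growth), compound 1 gives 3580 nM. Compound 2 `COc1cc(-c2cc(/C=C/C(=O)c3ccc(Cl)c(Cl)c3)[nH]n2)cc(OC)c1OC` carries a 3,4-dichlorophenyl in that place. In this assay compound 2 gives > 100000 nM, which is a limit of the assay and not a number (the limit of > 100000 nM in this assay, at which 1 of the 2 values shown sits). The step of an at least 27-fold higher number from compound 1 to compound 2 (1.44 log units; beyond the scatter) therefore places compound 2 at the weak end of what has been measured, with only a limit marking where it stands. Compound 3 `COc1ccc(C(=O)/C=C/c2cc(-c3cc(OC)c(OC)c(OC)c3)n[nH]2)cc1OC` differs from compound 2 by 3,4-dimethoxyphenyl in place of 3,4-dichlorophenyl on a carbonyl carbon. For the measured compounds named here, the only measured step that bears on this change is an at least 27-fold higher number from compound 1 to compound 2 (1.44 log units; beyond the scatter), which shows that exchanging the group on the carbonyl carbon can shift the result by a large amount. Compound 3 puts the 3,4-dimethoxyphenyl where compound 2 had the 3,4-dichlorophenyl, so a move back toward compound 1, though not all the way, is expected. Compound 3 is expected to give 12000 nM in this assay, with a range from 2500 nM to 100000 nM, meaning an expected step of an at least 8.3-fold lower number from compound 2 to compound 3 (0.92 log units; beyond the scatter).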

Compound 3, concentration for total growth inhibition: 3220 nM
Compound 3: middle estimate off by 3.7-fold (0.57 log units), on the high side; the measured number falls inside the stated range.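

The change on the carbonyl carbon gives an at least 31-fold lower number from compound 2 to compound 3 (1.49 log units; beyond the scatter), so leaving the 3,4-dichlorophenyl for the 3,4-dimethoxyphenyl matters a great deal in this assay, even though both groups keep the same six-membered aromatic ring of carbon only and differ in what that ring carries. The second new step reads a 1.1-fold lower number from compound 1 to compound 3 (0.05 log units; within the scatter), so the 3,4-dimethoxyphenyl and the 4-aminophenyl cannot be told apart here, and of the three groups shown at this place only the 3,4-dichlorophenyl stands apart. Compound 2 still rests on a limit of the assay and not on a number, which leaves the full size of its step unfixed: the limit of > 100000 nM in this assay, at which 1 of the 3 values shown sits.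

From the compounds shown here alone, with three groups in hand, it stays open whether a single chlorine, as in a 4-chlorophenyl, or a plain phenyl with no added group would fall with compound 2 or with compound 1 and compound 3. Going by these compounds, it is equally open how a 4-methoxyphenyl, a 3-aminophenyl or a 4-carboxyphenyl on the same carbonyl carbon would read in this assay.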